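A few compounds are considered here, and "the series" means these few. Any claim that something is new, unique, unknown or untested is made for them only; others in the source may bear on it.

Compound 1 `CC(=O)N1CC[C@@H](Oc2cncc(N3C(=O)c4ccc(Cl)cc4C3(C)C)c2)C1` has the higher of the two numbers in an assay on cells for inhibition of cytochrome P450 11B2, mitochondrial (Homo sapiens), read by HTRF (a lower number here means a stronger inhibitor, a higher number a weaker inhibitor), where compound 1 gives 11 nM; compound 2 `CCS(=O)(=O)N1CC(Oc2cncc(N3C(=O)c4ccc(Cl)cc4C3(C)C)c2)C1` gives 4 nM in this assay, a step of a 2.8-fold lower number from compound 1 to compound 2 (0.44 log units; beyond the scatter). Compound 3 `CC(=O)N1CCC(c2cncc(N3C(=O)c4ccc(Cl)cc4C3(C)C)c2)CC1` differs from compound 1 in one place: a group of 9 heavy atoms (7 carbon, 1 nitrogen, 1 oxygen; one six-membered non-aromatic ring with 1 hetero atom) in place of a group of 9 heavy atoms (6 carbon, 1 nitrogen, 2 oxygen; one five-membered non-aromatic ring with 1 hetero atom), on an aromatic carbon. The measured step concerns a different part of the molecule and does not bear directly on this change; nothing measured here tests a change of this kind, so the expectation carries wide uncertainty. For compound 3 the expected step is a 1.4-fold higher number from compound 1 to compound 3 (0.13 log units; within the scatter). The estimate for compound 3 in this assay is 15 nM, within 4 nM to 60 nM.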

Compound 3, half-maximal inhibitory concentration: 5 nM
The estimate for compound 3 lay 3.0-fold (0.48 log units) above the measured number, within the range that was stated.
By their numbers in this assay, from the lowest: compounds 2 and 3 (each within the scatter of the next); then compound 1.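

The change to 1-acetylpiperidin-4-yl on the aromatic carbon gives, in this assay, a 2.2-fold lower number from compound 1 to compound 3 (0.34 log units; beyond the scatter). This position therefore does not need an oxygen link to the non-aromatic ring for the number to fall, although ring size and link change together and cannot be separated here. No measurement available here explains this step. Still open, from the compounds shown here alone, is whether the same six-membered ring attached through oxygen would match compound 3. Also open, going by these compounds, is how a free piperidine amine or an ethylsulfonyl group on the piperidine nitrogen would compare with the acetyl group.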